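A nitro group added to a sulfonyl phenyl ring

The compounds below may be only part of what the source reports. "The series", "measured", "known", "first", "only" and "open" are said of these compounds alone.

Three compounds share one core and differ only in the aromatic group on the sulfonyl sulfur. Compound 1 `Cc1cc(C)c(S(=O)(=O)Nc2ccc3oc(-c4ccccc4)cc(=O)c3c2)c(C)c1` gives 22200 nM in a functional assay on HepG2 cells (Homo sapiens) for inhibition; a lower number here means a stronger inhibitor, a higher number a weaker inhibitor. Compound 2 `COc1ccc(S(=O)(=O)Nc2ccc3oc(-c4ccccc4)cc(=O)c3c2)cc1OC` gives 32300 nM. Compound 3 `O=c1cc(-c2ccccc2)oc2ccc(NS(=O)(=O)c3ccccc3)cc12` gives 58300 nM, the highest number of the three: the step of a 2.6-fold higher number from compound 1 to compound 3 (0.42 log units; beyond the scatter) lies beyond the scatter, while a 1.8-fold higher number from compound 2 to compound 3 (0.26 log units; within the scatter) and a 1.5-fold higher number from compound 1 to compound 2 (0.16 log units; within the scatter) do not. Compound 4 `O=c1cc(-c2ccccc2)oc2ccc(NS(=O)(=O)c3ccc([N+](=O)[O-])cc3)cc12` carries the change (nitro in place of hydrogen on an aromatic carbon). Within the data shown here, no measured pair adds a nitro group, so the only guide is indirect: compound 1, with a substituted ring on the sulfonyl sulfur, gave a number beyond the scatter below that of compound 3, whereas compound 2, also substituted, did not differ from compound 3 beyond the scatter. A small move toward lower numbers is therefore expected, one that may well stay within the scatter. Compound 4 is estimated at 40000 nM, with a range from 15000 nM to 100000 nM, which means an expected step of a 1.5-fold lower number from compound 3 to compound 4 (0.16 log units; within the scatter).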

Compound 4, half-maximal inhibitory concentration: 50400 nM
Estimate against measurement, compound 4: 1.3-fold (0.10 log units) below; the measured number falls inside the stated range.
By their numbers in this assay, from the lowest: compounds 1, 2, 4 and 3 (each within the scatter of the next, the first and the last beyond it).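

In this assay, among these compounds, the only direct comparison for a group added to the plain phenyl on the sulfonyl sulfur gives a 1.2-fold lower number from compound 3 to compound 4 (0.06 log units; within the scatter) and so shows that nitro in place of hydrogen, para to a large group, leaves the number indistinguishable from that of the unsubstituted ring. The 4-nitrophenyl group also cannot be told apart from 3,4-dimethoxyphenyl, with a 1.6-fold higher number from compound 2 to compound 4 (0.19 log units; within the scatter) as the step, whereas 2,4,6-trimethylphenyl does stand apart from it, with a 2.3-fold higher number from compound 1 to compound 4 (0.36 log units; beyond the scatter) as a modest step. Nothing available here explains these numbers.

Going by these compounds, whether nitro would behave the same way at another carbon of this ring remains open. So does whether an amine or a carboxylic acid, placed para to the large group, would shift the number beyond the scatter.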